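A Larger Amino Acid Side Chain on the Sulfonamide Core

The compounds below may be only part of what the source reports. "The series", "measured", "known", "first", "only" and "open" are said of these compounds alone.

Of the compounds shown here, three with a shared core have been measured in a functional assay on K562 cells (Homo sapiens) for cytotoxicity, read by trypan blue exclusion, with a stated time of 96 h; a lower number here means a stronger inhibitor, a higher number a weaker inhibitor. Compound 1 `COc1cc(OC)c(/C=C/S(=O)(=O)Nc2ccc(F)c(N)c2)c(OC)c1` gives 5000 nM, and compound 2 `COc1ccc(NS(=O)(=O)/C=C/c2c(F)cc(F)cc2F)cc1` gives 15000 nM. Compound 3 `COC(=O)C(C)Nc1cc(NS(=O)(=O)/C=C/c2c(OC)cc(OC)cc2OC)ccc1OC` gives 300 nM, the lowest of the three numbers, and its distance to compound 1 as well as to compound 2 lies beyond the scatter. Compound 4 `COc1cc(OC)c(/C=C/S(=O)(=O)Nc2ccc(OC)c(NC(C(=O)O)c3ccc(Cl)cc3)c2)c(OC)c1` has not yet been measured in this assay. It differs from compound 3 in one place: carboxy(4-chlorophenyl)methyl in place of 1-(methoxycarbonyl)ethyl on a nitrogen on an aromatic ring. Among the measured compounds shown here, no measured pair shows this same change, so its effect is unknown. The expected step in this assay is a 2.0-fold higher number from compound 3 to compound 4 (0.30 log units; within the scatter), modest and toward a higher number, possibly within the scatter. The estimate for compound 4 is 600 nM, within a range from 150 nM to 3000 nM.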

Compound 4, half-maximal inhibitory concentration: 15 nM
Compound 4: the middle estimate sits 40-fold (1.60 log units) above what was measured; measured number below the stated range.
By their numbers in this assay, from the lowest: compound 4; then compound 3; then compound 1; then compound 2.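

In this assay the position on a nitrogen on an aromatic ring proves highly responsive: carboxy(4-chlorophenyl)methyl in place of 1-(methoxycarbonyl)ethyl gives a 20-fold lower number from compound 3 to compound 4 (1.30 log units; beyond the scatter) even though the entering group is larger and carries an aromatic ring. This is the first single-place step among the compounds, and no measurement shown accounts for its size. The compounds shown leave open whether the carboxylic acid, the phenyl ring or its chlorine carries the step. A phenyl group without chlorine, or a methyl ester in place of the carboxylic acid, would separate these contributions.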